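The source may report more compounds than this note shows. Statements on the series, on what has been measured and on what is new or still open speak of the compounds shown alone.

Compound 1 `CC(C)n1ncc2c(C(=O)Nc3cccc(C(N)=O)c3)cc(-c3cccs3)nc21` stands at 25000 nM in an ADME assay on LLC-MK2 cells (Macaca mulatta) for cytotoxicity, read by spectrophotometry and crystal violet staining, with a stated time of 4 days (on this read-out lower numbers stand for higher toxicity in this test and higher numbers for lower toxicity in this test), level with compound 2 `CNS(=O)(=O)c1cccc(NC(=O)c2cc(-c3cccs3)nc3c2cnn3C(C)C)c1`, which gives 25000 nM, so that no change at the digits printed from compound 1 to compound 2 (within the scatter) shows no change within the scatter. Compound 3 `CC(C)n1ncc2c(C(=O)Nc3ccc(F)cc3)cc(-c3ccco3)nc21` gives only a limit of this assay, > 200000 nM, which is the limit of > 200000 nM in this assay, at which 1 of the 3 values shown sits. Compound 4 `CC(C)n1ncc2c(C(=O)Nc3cc(C(N)=O)ccc3F)cc(-c3cccs3)nc21` differs from compound 1 by fluoro in place of hydrogen on an aromatic carbon. For the measured compounds named here, the single measured step exchanged one group for another on an aromatic carbon and moved the read-out not at all; no measured step adds fluoro in place of hydrogen, so none bears directly on this change. Compound 4 is therefore expected to sit close to compound 1, with an expected step of no change at the digits printed from compound 1 to compound 4 (within the scatter). Compound 4 is estimated at 25000 nM, within 10000 nM to 60000 nM.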

Compound 4, half-maximal cytotoxic concentration: 25000 nM
Beside the measured number, compound 4's estimate shows no gap at the digits printed; the range from low to high includes it.
By their numbers in this assay, from the lowest: compounds 1, 2 and 4 (each within the scatter of the next). At a limit, above all of these: compound 3.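

In this assay, the step reads no change at the digits printed from compound 1 to compound 4 (within the scatter). For the compounds shown here, this is the first measured change that adds fluoro to the six-membered aromatic ring carrying the carbamoyl group, and at this place, ortho to a large group and para to the carbamoyl group, the read-out stays level. The data shown offer no explanation for this result. Going by these compounds, it remains open whether an amine or a methoxy group at this same place would also leave the read-out level. On these data alone, whether fluoro would do so elsewhere on this ring also remains open.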